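Solubility of an Ether-Linked Amide Series: Compound 3 to 4

The compounds below may be only part of what the source reports. "The series", "measured", "known", "first", "only" and "open" are said of these compounds alone.

Of the compounds shown here, three of a shared core have been measured in a physicochemical assay for solubility, in phosphate buffer, measured as kinetic solubility, with a stated time of 1 h, at pH 7.4; on this read-out lower numbers stand for lower solubility and higher numbers for higher solubility. Compound 1 `CCOc1ccc2nc(C(F)(F)F)cc(OCC(=O)Nc3cc(C)cc(C)c3)c2c1` sits at a limit of this assay, < 1000 nM, which is a limit rather than a number, as the assay reports (the limit of < 1000 nM in this assay, at which 1 of the 3 values shown sits). Compound 2 `COc1ccc2nc(C)c(NC(=O)C(=O)Nc3cc(C)cc(C)c3)c(O)c2c1` gives 10000 nM in this assay. Compound 3 `COc1ccc2nc(C)cc(OCC(=O)Nc3cccc(C)c3)c2c1` gives 193000 nM in this assay, the highest of the two actual numbers; its nearest neighbour is compound 2, whose number is lower by a gap that lies beyond the usual scatter of repeated measurements.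

Compound 4 `COc1ccc2nc(C)cc(OCC(=O)Nc3cc(F)cc(F)c3)c2c1` has not yet been measured. It differs from compound 3 in one place: 3,5-difluorophenyl in place of 3-methylphenyl on an amide-type nitrogen. Among the compounds with values here, no measured pair in this set shows the same change, so the expected size of the step rests only on the closeness of the two structures. For compound 4 the expectation is a small downward step from compound 3, a 1.9-fold lower number from compound 3 to compound 4 (0.29 log units; within the scatter), or none beyond the scatter. Compound 4 is therefore estimated to give about 100000 nM in this assay, within a range from 30000 nM to 250000 nM.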

Compound 4, solubility: 13000 nM
Beside the measured number, compound 4's estimate is 7.7-fold (0.89 log units) above it; measured number below the stated range.
By their numbers in this assay, from the lowest: compounds 2 and 4 (each within the scatter of the next); then compound 3. At a limit, below all of these: compound 1.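

In this assay, 3,5-difluorophenyl in place of 3-methylphenyl on an amide-type nitrogen gives a 15-fold lower number from compound 3 to compound 4 (1.17 log units; beyond the scatter), a large step and the first in this set that can be read between two compounds differing in one place. It shows that this position is not a silent one: both groups are a six-membered aromatic ring of carbon only, with no hydrogen-bond donors, no hydrogen-bond acceptors and no net charge, and yet the number moves well beyond the scatter of repeated measurements. Nothing measured here accounts for the size of this step.

The compounds shown leave open whether the step follows the loss of the methyl group or the arrival of the fluorines, and a plain phenyl or a 3-fluorophenyl on the same nitrogen would help to separate the two. Also open, from the compounds shown here alone, is how a different kind of group at this place, such as a pyridine ring or a phenyl carrying a carboxylic acid, would read in this assay, and whether the same change gives a step of similar size on another core.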